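The source may report more compounds than this note shows. Statements on the series, on what has been measured and on what is new or still open speak of the compounds shown alone.

Compound 1, `CSc1ccc(CNc2nc(SC)nc3ncccc23)cc1`, is one of three compounds tested in a functional assay on CCRF-CEM cells (Homo sapiens) for cytotoxicity, read by MTT assay, with a stated time of 72 h (on this read-out higher numbers stand for lower toxicity in this test and lower numbers for higher toxicity in this test), and in that test compound 1 gives 59000 nM. Compound 2, `COc1ccc(CNc2nc([SeH])nc3ccccc23)cc1`, reaches only the limit of the test, and in this assay compound 2 gives > 100000 nM. Compound 3, `CSc1ccc(CNc2nc([SeH])nc3ccccc23)cc1`, also stops at the limit, and in this assay compound 3 gives > 100000 nM. Among the compounds with values here, compound 1 thus holds the only number here; the other two values sit at the limit of > 100000 nM in this assay, at which 2 of the 3 values shown sit. The difference between the core of compound 1 and the core of compound 3 is not broken down here. Compound 2 differs from compound 3 by methoxy in place of methylsulfanyl on an aromatic carbon, and the step that the two limits leave unreadable from compound 3 to compound 2 has no readable size, since both ends are limits. Compound 4, `COc1ccc(CNc2nc(SC)nc3ncccc23)cc1`, has not yet been tested in this assay. Within the data shown here, it differs from compound 1 by methoxy in place of methylsulfanyl on an aromatic carbon, the same change as the one from compound 3 to compound 2. That earlier step gives no guidance on size. The expectation therefore rests on compound 1 with 59000 nM, taken as the starting point. In this assay the expected step is a 1.2-fold higher number from compound 1 to compound 4 (0.07 log units; within the scatter). Compound 4 is estimated at 70000 nM, within a range from 25000 nM to 200000 nM.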

Compound 4, concentration lethal to 50% of the cells: > 100000 nM
Compound 4 ended at the assay's limit; the forecaster's own chance of this, stated with the estimate: 35%; at least 1.4-fold (0.15 log units) between middle value and limit.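

In this assay, methoxy in place of methylsulfanyl on an aromatic carbon gives an at least 1.6-fold higher number from compound 1 to compound 4 (0.22 log units; that floor lies within the scatter). From the compounds shown here alone, for compound 4, the result of > 100000 nM is a limit of the test and not a number, so only a floor is known, the true size of the step stays unknown, and that floor does not establish a real change. The same swap on the core of compound 3 joins two limits and cannot be read, which leaves no size to carry from one core to the other and no test of whether the swap behaves alike on both: the limit of > 100000 nM in this assay, at which 3 of the 4 values shown sit.

Going by these compounds, it remains open how other groups would read at the same place on the core of compound 1, for example an amine or a carboxylic acid in place of methylsulfanyl. Also open, on these data alone, is whether any such group would give a measured number in this test, or whether it would stop at the limit as methoxy does.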